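The compounds below may be only part of what the source reports. "The series", "measured", "known", "first", "only" and "open" are said of these compounds alone.

Compound 1 `CN(C)CCCCCn1c2c(c3ccccc31)C(=O)c1c[n+]([O-])c3ccccc3c1C2=O`: 200 nM
Compound 2 `O=C1c2c[n+]([O-])c3ccccc3c2C(=O)c2c1c1ccccc1n2Cc1cn([C@@H]2C[C@H](O)[C@@H](CO)O2)nn1`: 110 nM
Compound 3 `O=C1c2c[n+]([O-])c3ccccc3c2C(=O)c2c1c1ccccc1n2CCCCN1CCNCC1`: 12000 nM

In a functional assay on MCF7 cells (Homo sapiens) for cytotoxicity, read by MTT assay, with a stated time of 72 h (a lower number here means a stronger inhibitor, a higher number a weaker inhibitor), compound 2 gives 110 nM, within the usual scatter of compound 1 at 200 nM, while compound 3 lies far higher at 12000 nM.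

Compound 4 `CC1(C)OC[C@@H](Cn2cc(Cn3c4c(c5ccccc53)C(=O)c3c[n+]([O-])c5ccccc5c3C4=O)nn2)O1` changes compound 2 on an aromatic nitrogen: (2,2-dimethyl-1,3-dioxolan-4-yl)methyl in place of 4-hydroxy-5-(hydroxymethyl)oxolan-2-yl on an aromatic nitrogen. For the measured compounds named here, no measured step covers this swap. The only one, a 60-fold higher number from compound 1 to compound 3 (1.78 log units; beyond the scatter), concerns a different side chain and warns that one change can matter greatly. Yet compound 1, with a very different side chain, gives 200 nM, close to compound 2. A small step is therefore expected in this assay, slightly upward and not clearly beyond the scatter: a 1.8-fold higher number from compound 2 to compound 4 (0.26 log units; within the scatter). The estimated value for compound 4 is 200 nM, with an expected range of 50 nM to 1000 nM.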

Compound 4, half-maximal inhibitory concentration: > 1000 nM
Compound 4 was reported as a limit; the forecaster's own chance of this, stated with the estimate: 3%; middle value at least 5.0-fold (0.69 log units) away from the limit.
By their numbers in this assay, from the lowest: compounds 2 and 1 (each within the scatter of the next); then compound 3.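

In this assay, the group on this aromatic nitrogen of the triazole-like five-membered aromatic ring with 3 nitrogen matters even when its size stays the same: both groups have 8 heavy atoms, yet the change gives an at least 9.0-fold higher number from compound 2 to compound 4 (0.95 log units; beyond the scatter). The value for compound 4 is a limit of the assay, not a number: the limit of > 1000 nM in this assay, at which 1 of the 4 values shown sits.

The swap alters hydrogen-bond donors (2 to 0), ring type and stereocentres all at once, so the compounds shown cannot tell which of these counts. A 2,3-dihydroxypropyl group on this nitrogen remains an open comparison.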